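The compounds below may be only part of what the source reports. "The series", "measured", "known", "first", "only" and "open" are said of these compounds alone.

Compound 1 `COc1ccccc1/C=C/C(=O)OC/C=C/c1cc(OC)c(OC)cc1OC` is one of three esters sharing a common core. In a functional assay on the whole organism (strain Kunming) with Mus musculus as the target, with a stated time of 0.5 h, at a dose of 300 mg/kg by the intraperitoneal route (on this read-out higher numbers stand for a weaker effect at the one dose given and lower numbers for a stronger effect), compound 1 gives 50%. Compound 2 `COc1cc(OC)c(OC)cc1/C=C/COC(=O)/C=C/c1c(OC)ccc(OC)c1OC` gives 50% in this assay, which sits level with compound 1 within the scatter, so the two together hold the highest numbers of the set. Compound 3 `COc1cc(OC)c(OC)cc1/C=C/COC(=O)/C=C/c1cc(OC)c(OC)c(OC)c1OC` gives 0% in this assay, a value clearly lower than that of compound 1 and beyond the scatter. Compound 4 `COc1cc(OC)c(OC)cc1/C=C/COC(=O)/C=C/c1cccc(Br)c1` has not yet been measured; it differs from compound 1 by 3-bromophenyl in place of 2-methoxyphenyl on a double-bonded chain carbon bound to a double-bonded chain carbon. Within the data shown here, no step between measured compounds matches this change, so the expected size of the step from compound 1 is uncertain; the account expects a modest step toward a lower number, a number 10 percentage points lower from compound 1 to compound 4 (within the scatter), in this assay. For compound 4 the estimate is 40%, with a range from 0% to 90%.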

Compound 4, a percentage reported as activity, at one dose (the size of the read-out at that dose, not a potency): 25%
Beside the measured number, compound 4's estimate is 15 percentage points above it; the range from low to high includes it.
By their numbers in this assay, from the lowest: compound 3; then compound 4; then compounds 1 and 2 (each within the scatter of the next).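

In this assay, 3-bromophenyl in place of 2-methoxyphenyl on a double-bonded chain carbon bound to a double-bonded chain carbon gives a number 25 percentage points lower from compound 1 to compound 4 (beyond the scatter) and thus a stronger effect at the one dose given. Among these compounds, this is the first readable step at this place, and it shows that the effect does not depend on a methoxy group on this ring. Nothing measured here explains the step. The compounds shown leave open whether the step comes from gaining the bromine or from losing the methoxy group, and how an amine or a carboxylic acid on this ring would read.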